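Ethyl chromone ethers: bromine and trifluoromethyl in one compound

This account rests on a few compounds, and the source may have more. Where it says the series, first, only, none or still open, it means among the compounds named here.

compound 1 `CCc1cc(=O)c2ccc(OCc3cccc(C(F)(F)F)c3)c(C)c2o1` — > 27600 nM
compound 2 `CCc1oc2c(C)c(OCc3ccccc3)ccc2c(=O)c1Br` — > 26700 nM

In a functional assay on KBVIN cells (Homo sapiens) for antiproliferative activity, read by sulforhodamine B assay, with a stated time of 72 h (on this read-out lower numbers stand for stronger inhibition of growth and higher numbers for weaker inhibition of growth), compound 2 gives > 26700 nM, which is a limit of the assay and not a number. Compound 2 therefore sits at the limit of > 26700 nM in this assay, at which 1 of the 2 values shown sits. Compound 1 gives > 27600 nM, also a limit, at the limit of > 27600 nM in this assay, at which 1 of the 2 values shown sits. Going by the values given here, both values shown are limits, so no step between measured compounds can be read.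

Compound 3 `CCc1oc2c(C)c(OCc3cccc(C(F)(F)F)c3)ccc2c(=O)c1Br` differs from compound 2 by trifluoromethyl in place of hydrogen on an aromatic carbon. Compound 2 is already at a limit, and compound 1, which carries the same trifluoromethyl, is at one as well, so no step beyond the scatter is expected. The expected step is a step that the limit leaves unreadable from compound 2 to compound 3. Compound 3 is estimated at 30000 nM, within 10000 nM to 100000 nM, most likely again reported as a limit.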

Compound 3, concentration for 50% growth inhibition: > 22600 nM
Compound 3 gave a limit, no number (the forecaster's own chance of this, stated with the estimate: 85%); the middle value lies beyond the limit too.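

In this assay, going by these compounds alone, compound 1, compound 2 and compound 3 all give limits, and no step among them can be read. On these data alone, what trifluoromethyl or bromo does to growth inhibition on the shared core remains open.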